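A few compounds are considered here, and "the series" means these few. Any claim that something is new, unique, unknown or untested is made for them only; others in the source may bear on it.

Measured so far:
- compound 1, `CC(C)Cc1cc2oc(=O)n(CCC(=O)O)c2cc1Cl` — 794 nM
- compound 2, `CCOc1cc2oc(=O)n(CCC(=O)O)c2cc1Cl` — 398 nM

Both numbers come from an assay on HEK293 cells for inhibition of kynurenine 3-monooxygenase (Homo sapiens), read by LC-MS, with a stated time of 20 h; a higher number here means a weaker inhibitor, a lower number a stronger inhibitor. Compound 1 gives 794 nM in this assay, and compound 2 gives 398 nM; the step of a 2.0-fold lower number from compound 1 to compound 2 (0.30 log units; within the scatter) stays within the usual scatter, so the two compounds stand together rather than apart, compound 2 holding the smaller of the two readings.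

Compound 3, `C[C@@H](Oc1cc2oc(=O)n(CCC(=O)O)c2cc1Cl)c1ncccn1`, differs from compound 2 in one place: pyrimidin-2-yl in place of hydrogen on a saturated chain carbon bound to an oxygen on an aromatic ring and a saturated chain carbon. Among the compounds with values here, no measured step touches that place; the only step on record, a 2.0-fold lower number from compound 1 to compound 2 (0.30 log units; within the scatter), changes a group on the aromatic ring, not on the chain carbon bound to the oxygen. There is thus no measured basis for expecting a step beyond the scatter in either direction.

Compound 3 is therefore expected near the value of compound 2, at an estimated 320 nM with a range of 100 nM to 1000 nM, an expected step of a 1.2-fold lower number from compound 2 to compound 3 (0.09 log units; within the scatter).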

Compound 3, half-maximal inhibitory concentration: 3160 nM
Compound 3: the middle estimate sits 9.9-fold (0.99 log units) below what was measured, and the stated range ends below it.
By their numbers in this assay, from the lowest: compounds 2 and 1 (each within the scatter of the next); then compound 3.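

Putting pyrimidin-2-yl in place of hydrogen on the saturated chain carbon bound to the oxygen gives a 7.9-fold higher number from compound 2 to compound 3 (0.90 log units; beyond the scatter) in this assay, so the larger group here goes with a weaker inhibitor. Within the data shown here, this is the first step to lie beyond the scatter, which marks this chain carbon as a place where a change can move the reading clearly. The earlier pair, with its change on an aromatic carbon, could not show this, and no measurement available here explains the loss.

The compounds shown leave open whether this loss belongs to pyrimidin-2-yl itself or would follow any added group on this carbon. A methyl group or a plain phenyl ring at the same place would help separate those two readings.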